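The source may hold more compounds than are shown below. What is called first, only, known or untested is meant among the compounds shown, and "the series" means these compounds.

The measured compounds: compound 1 `c1ccc(Oc2ccc3c(NCCCNCc4ccco4)ccnc3c2)cc1`, 14500 nM; compound 2 `CC(C)CCc1ccc2c(NCCCNCc3ccco3)ccnc2c1`, 4200 nM; compound 3 `Fc1ccc(Cc2ccc3c(NCCCNCc4ccco4)ccnc3c2)c(Cl)c1`, 4200 nM.

All three were measured in a physicochemical assay for solubility, with a stated time of 18 h, at pH 7.4; a lower number here means a less soluble compound, a higher number a more soluble compound. Compound 1 stands highest of the three: the step of a 3.5-fold lower number from compound 1 to compound 2 (0.54 log units; beyond the scatter) and the step of a 3.5-fold lower number from compound 1 to compound 3 (0.54 log units; beyond the scatter) both lie beyond the scatter, whereas between compound 2 and compound 3 no change at the digits printed from compound 2 to compound 3 (within the scatter). Compound 4 `CC(C)(C)c1ccc(Oc2ccc3c(NCCCNCc4ccco4)ccnc3c2)cc1` has not yet been measured; it differs from compound 1 by tert-butyl in place of hydrogen on an aromatic carbon. Within the data shown here, no measured step adds a group onto the phenoxy in this way, but the two steps from compound 1, each replacing the phenoxy with another group, both lowered the number, so a modest drop is expected: a 4.1-fold lower number from compound 1 to compound 4 (0.62 log units; beyond the scatter). Compound 4 is therefore estimated at 3500 nM, within 1000 nM to 10000 nM.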

Compound 4, solubility: 14500 nM
Compound 4: middle estimate off by 4.1-fold (0.62 log units), on the low side; measured number above the stated range.
By their numbers in this assay, from the lowest: compounds 2 and 3 (each within the scatter of the next); then compounds 1 and 4 (each within the scatter of the next).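

In this assay, tert-butyl on an aromatic carbon of the phenoxy ring, the change from phenyl to 4-(tert-butyl)phenyl, gives no change at the digits printed from compound 1 to compound 4 (within the scatter) and so leaves the number level. The earlier steps shown here from compound 1 replaced the whole phenoxy and lowered the number, whereas this one keeps the phenoxy and adds to it. Nothing measured here bears on the reason for this result. Still open, on these data alone, is whether an amine or a carboxylic acid at this place would also leave the number level. Also open, as far as these compounds go, is what tert-butyl would do on another carbon of that ring.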